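The source may hold more compounds than are shown below. What is called first, only, known or untested is meant among the compounds shown, and "the series" means these compounds.

Measured compounds in the series:

- compound 1, `Cc1ccc(S(=O)(=O)Cc2ccccc2)cc1C#Cc1cc(Cl)ccc1OCC(=O)O`: in an assay on CHO cells for displacement of a labelled ligand from prostaglandin D2 receptor 2 (Homo sapiens), read by scintillation counting (on this read-out higher numbers stand for weaker inhibition and lower numbers for stronger inhibition), compound 1 gives 5 nM
- compound 2, `Cn1ccnc1C#Cc1cc(Cl)ccc1OCC(=O)O`: in this assay compound 2 gives 1470 nM
- compound 3, `CCCc1ccncc1C#Cc1cc(Cl)ccc1OCC(=O)O`: in this assay compound 3 gives 4.3 nM

Compound 1 stands second highest of the three numbers. Its value and that of compound 3 lie within the scatter of each other, so no order between them can be read. Compound 2 is far apart: its number is beyond the scatter higher than that of compound 1, and that is the only gap among the measured compounds that exceeds the scatter.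

The compound to be measured is compound 4, `Cc1ccc(S(=O)(=O)N2CCCCC2C)cc1C#Cc1cc(Cl)ccc1OCC(=O)O`. Compared with compound 1 it differs in one place: 2-methylpiperidin-1-yl in place of benzyl on a sulfonyl sulfur. The group that leaves and the group that enters are of equal heavy-atom count, each a single six-membered ring, neither carrying a hydrogen-bond donor or acceptor. Among the measured compounds shown here, no step between measured compounds touches this position, so the size of the change in this assay is not anchored by data.

The expectation for compound 4 is a step of a 1.6-fold higher number from compound 1 to compound 4 (0.20 log units; within the scatter), that is, a value not beyond the scatter from compound 1, leaning slightly toward a higher number. Compound 4 is estimated at 8 nM, within a range of 2 nM to 40 nM.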

Compound 4, inhibition constant: 1.9 nM
Compound 4: middle estimate off by 4.2-fold (0.62 log units), on the high side; the whole stated range lies above it.
By their numbers in this assay, from the lowest: compound 4; then compounds 3 and 1 (each within the scatter of the next); then compound 2.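

In this assay the change to 2-methylpiperidin-1-yl in place of benzyl on a sulfonyl sulfur brings a 2.6-fold lower number from compound 1 to compound 4 (0.42 log units; beyond the scatter) as a modest step, the first measured at this position. The position therefore does not depend on the benzyl group for a low number: a non-aromatic ring attached through its nitrogen, of equal heavy-atom count, gives a lower number than the aromatic ring of compound 1. No measurement on hand accounts for the size or direction of this step.

From the compounds shown here alone, the part played by the methyl group remains open, and plain piperidin-1-yl on the same sulfonyl sulfur would separate it from the ring. Morpholin-4-yl or an open-chain dimethylamino group there would test how far the ring itself can vary.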